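Swapping the Aryl Group for a Styryl Arm

The compounds below may be only part of what the source reports. "The series", "measured", "known", "first", "only" and "open" are said of these compounds alone.

Measured so far in an ADME assay on HeLa cells (Homo sapiens) for cytotoxicity, read by MTT assay, with a stated time of 72 h; on this read-out lower numbers stand for higher toxicity in this test and higher numbers for lower toxicity in this test:
compound 1, `Clc1ccc(/C=N/c2sc3c(c2-c2nc4ccccc4s2)CCCC3)cc1`, gives 431 ug/mL
compound 2, `Clc1ccc(/C=N/c2sc3c(c2-c2nc4ccccc4s2)CCCC3)c(Cl)c1`, gives 542 ug/mL
compound 3, `FC(F)(F)c1ccc(/C=N/c2sc3c(c2-c2nc4ccccc4s2)CCCC3)cc1`, gives 369 ug/mL

Compound 3 holds the lowest of the three numbers, yet the steps of a 1.2-fold lower number from compound 1 to compound 3 (0.07 log units; within the scatter) and a 1.5-fold lower number from compound 2 to compound 3 (0.17 log units; within the scatter) both stay within the scatter, so the three compounds cannot be told apart on this read-out. Compound 4, `C(=C/c1ccccc1)\C=N\c1sc2c(c1-c1nc3ccccc3s1)CCCC2`, alters the same spot: 2-phenylethenyl in place of 4-(trifluoromethyl)phenyl on a carbon with a double bond to nitrogen. Among the measured compounds shown here, the steps that bear on it, a 1.2-fold lower number from compound 1 to compound 3 (0.07 log units; within the scatter) and a 1.5-fold lower number from compound 2 to compound 3 (0.17 log units; within the scatter) at this carbon and a 1.3-fold higher number from compound 1 to compound 2 (0.10 log units; within the scatter) on the aromatic ring, all stayed within the scatter. For the measured compounds named here, no measured step replaces the aromatic ring itself with a chain carrying a double bond, so the expectation is simply no step beyond the scatter. Compound 4 is expected to give 400 ug/mL, with a range from 180 ug/mL to 900 ug/mL. The expected step is a 1.1-fold higher number from compound 3 to compound 4 (0.04 log units; within the scatter).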

Compound 4, half-maximal cytotoxic concentration: 389 ug/mL
Beside the measured number, compound 4's estimate is 1.0-fold (0.01 log units) above it, within the range that was stated.
By their numbers in this assay, from the lowest: compounds 3, 4, 1 and 2 (each within the scatter of the next).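

In this assay, the 2-phenylethenyl arm, with its double bond outside the aromatic ring, stays within the scatter of all three aryl compounds (a 1.1-fold higher number from compound 3 to compound 4 (0.02 log units; within the scatter); a 1.1-fold lower number from compound 1 to compound 4 (0.04 log units; within the scatter); a 1.4-fold lower number from compound 2 to compound 4 (0.14 log units; within the scatter)). The lack of separation seen among the aryl groups on this carbon therefore extends to a chain carrying a double bond and a phenyl ring. No evidence is available to explain this flat result. On these data alone, all four compounds keep a phenyl ring in this group, so it remains open whether a saturated alkyl chain, an amine or a carboxylic acid on this carbon would move the number beyond the scatter.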